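Amine chain variation on the chloro-biaryl methoxyphenyl series

The source may report more compounds than this note shows. Statements on the series, on what has been measured and on what is new or still open speak of the compounds shown alone.

Measured so far:
compound 1, `COc1ccccc1-c1cc(C2CCN(C)C2)ccc1Cl` — 646 nM; 650 nM (2 entries)
compound 2, `CCNCc1ccc(Cl)c(-c2ccccc2OC)c1` — "not active" (no number reported)
compound 3, `COc1ccccc1-c1cc(CN(C)C)ccc1Cl` — 479 nM; 480 nM (2 entries)

In a functional assay on HEK293 cells for agonist activity at 5-hydroxytryptamine receptor 7 (Homo sapiens), read by a luciferase reporter and beta-arrestin recruitment, with a stated time of 22 h (a lower number here means that less compound is needed, a higher number that more compound is needed for the effect), compound 1 gives 646 nM; 650 nM (2 entries) (the several entries of compound 1 in this assay, 646 nM; 650 nM (2 entries)) and compound 3 gives 479 nM; 480 nM (2 entries) (the several entries of compound 3 in this assay, 479 nM; 480 nM (2 entries)); these two values lie within the scatter of each other. Compound 2 is reported only as "not active" (no number reported) in this assay, with no number; its further entries also give none. Compound 4, `CCCCNCc1ccc(Cl)c(-c2ccccc2OC)c1`, differs from compound 2 by ethyl in place of hydrogen on a saturated chain carbon, two bonds along the chain from an amine nitrogen. No measured pair covers a change of this kind, so the size of the step cannot be read from the shown data. Starting from a compound without a reported number, compound 4 is expected to remain weak, estimated at 6000 nM with a range of 1000 nM to 40000 nM in this assay, and a considerable chance that again no number is reported.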

Compound 4, half-maximal effective concentration: "not active" (no number reported)
Compound 4: no number reported; no gap can be computed for the estimate.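

In this assay, compound 2 and compound 4 both stand as "not active" without a number, so no step can be read between them. No available evidence bears on this result. The compounds shown leave open what separates these two from compound 1 and compound 3.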